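From compound 2 to compound 3: a group removed

This account rests on a few compounds, and the source may have more. Where it says the series, first, only, none or still open, it means among the compounds named here.

Compound 1 (`CCC(=O)Nc1ccc(C[C@H]2C(=O)OC[C@@H]2Cc2ccc(OC)c(OC)c2)cc1OC`) and compound 2 (`COc1cc(C[C@H]2C(=O)OC[C@@H]2Cc2ccc(OC)c(OC)c2)ccc1Nc1ccc(F)cc1`) were both tested in an ADME assay on A549 cells (Homo sapiens) for cytotoxicity, read by MTT assay, with a stated time of 4 days; on this read-out higher numbers stand for weaker inhibition and lower numbers for stronger inhibition. Compound 1 gives > 50000 nM, which is a limit of the assay and not a number. Compound 2 gives > 50000 nM, which is also a limit. Among the measured compounds shown here, compound 2 therefore has no exact value, and the same is true of the only other compound measured.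

Compound 3 (`COc1cccc(C[C@H]2C(=O)OC[C@@H]2Cc2ccc(OC)c(OC)c2)c1`) has not been measured yet. It differs from compound 2 by one change: hydrogen in place of (4-fluorophenyl)amino on an aromatic carbon. In words, hydrogen stands in place of (4-fluorophenyl)amino on an aromatic carbon.

For the measured compounds named here, the one measured step that bears on this is a step that the two limits leave unreadable from compound 1 to compound 2. It offers no size to carry over to the new change. Because of the limit of > 50000 nM in this assay, at which 2 of the 2 values shown sit, no step beyond the usual scatter is expected in this assay, and no direction can be given. The step expected is a step that the limit leaves unreadable from compound 2 to compound 3. For compound 3 the estimated value is 60000 nM, with an expected range of 25000 nM to 100000 nM.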

Compound 3, half-maximal inhibitory concentration: > 50000 nM
Compound 3 gave a limit, no number (the forecaster's own chance of this, stated with the estimate: 85%); the middle value lies beyond the limit too.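

No step can be read among compound 1, compound 2 and compound 3, because each gives a limit of the assay and not a number: the limit of > 50000 nM in this assay, at which 3 of the 3 values shown sit.

The compounds shown leave open how far apart these three truly lie in this assay, and whether any of the changes between them shifts the result at all.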